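The source may report more compounds than this note shows. Statements on the series, on what has been measured and on what is new or still open speak of the compounds shown alone.

For the measured compounds named here, in a functional assay on HeLa cells (Homo sapiens) for inhibition, read by MTT assay, with a stated time of 72 h (on this read-out lower numbers stand for stronger inhibition and higher numbers for weaker inhibition), three compounds built on a shared core have numbers so far. Compound 2 (`Clc1ccc(Nc2nnc(-c3c[nH]c4ccccc34)o2)cc1`) gives 3800 nM there, the lowest of the three. Compound 1 (`O=[N+]([O-])c1cccc(Nc2nnc(-c3c[nH]c4ccccc34)o2)c1`) gives 15100 nM and compound 3 (`Clc1ccc(Nc2nnc(-c3c[nH]c4ccccc34)o2)cc1Cl`) gives 19300 nM on the same read-out.

Compound 4 (`Cc1ccc(Nc2nnc(-c3c[nH]c4ccccc34)o2)cc1`) is still unmeasured. It differs from compound 2 in one place, with methyl in place of chloro on an aromatic carbon, so 4-chlorophenyl becomes 4-methylphenyl.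

Going by the values given here, only one measured step changes a single place: a 5.1-fold higher number from compound 2 to compound 3 (0.71 log units; beyond the scatter) when chloro takes the place of hydrogen on an aromatic carbon. That step is modest, and it shows that one small change can move the number beyond the usual scatter in this set. It does not swap chloro for methyl, so it offers only a rough guide to size. Compound 2 at 3800 nM lies under the other two numbers, so a higher number seems the likelier direction, though the data do not settle this.

The expected outcome is a 1.4-fold higher number from compound 2 to compound 4 (0.16 log units; within the scatter) in this assay as a small shift at most. For compound 4 the estimated value is 5500 nM with an expected range from 2200 nM to 14000 nM on this read-out.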

Compound 4, half-maximal inhibitory concentration: 15800 nM
Estimate against measurement, compound 4: 2.9-fold (0.46 log units) below; measured number outside the range, above it.
By their numbers in this assay, from the lowest: compound 2; then compounds 1, 4 and 3 (each within the scatter of the next).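

In this assay, putting methyl in place of chloro gives a 4.2-fold higher number from compound 2 to compound 4 (0.62 log units; beyond the scatter), so at this place, para to a large group, two groups of one heavy atom each are not interchangeable. For the compounds shown here, the only earlier step between compounds differing in one place, a 5.1-fold higher number from compound 2 to compound 3 (0.71 log units; beyond the scatter), added a chloro while keeping the one at this place, whereas the new step changes the group at this place itself, and here too the number rises beyond the scatter. Nothing in the available data gives a reason for the difference between chloro and methyl.

With only chloro and methyl to compare at this place, the compounds shown leave open how hydrogen, a methoxy group or an amine would fare there, and whether any group would give a lower number than chloro does. They also leave open whether the same exchange of chloro for methyl would produce a step of similar size and direction on a different core, or in another kind of cell.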